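Removing the Side Chain from Compound 3

A few compounds are considered here, and "the series" means these few. Any claim that something is new, unique, unknown or untested is made for them only; others in the source may bear on it.

Measured so far in a functional assay on ileum for inhibition of histamine H1 receptor (Cavia porcellus); on this read-out lower numbers stand for stronger inhibition and higher numbers for weaker inhibition: compound 1 `CCCCCCCn1c(N2CCN(C)CC2)nc2ccccc21` gives 150 nM; compound 2 `CN1CCN(c2nc3ccccc3n2CCOCCO)CC1` gives 42 nM; compound 3 `CCSCCCn1c(N2CCN(C)CC2)nc2ccccc21` gives 530 nM.

Compound 3 stands highest of the three numbers, beyond the scatter of both others. The next compound 4 `CN1CCN(c2nc3ccccc3[nH]2)CC1` carries hydrogen in place of 3-(ethylsulfanyl)propyl on an aromatic nitrogen. Going by the values given here, no measured step removes the whole chain; the steps seen only alter it: a 3.6-fold lower number from compound 1 to compound 2 (0.55 log units; beyond the scatter), a 3.5-fold higher number from compound 1 to compound 3 (0.55 log units; beyond the scatter) and a 13-fold higher number from compound 2 to compound 3 (1.10 log units; beyond the scatter). Those changes moved this assay by modest to large amounts in both directions, so the chain matters, and its complete loss is expected to raise the number modestly, as a 2.8-fold higher number from compound 3 to compound 4 (0.45 log units; beyond the scatter). For compound 4 the estimate is 1500 nM, within 300 nM to 8000 nM.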

Compound 4, half-maximal inhibitory concentration: > 3000 nM
Compound 4 was reported as a limit; the forecaster's own chance of this, stated with the estimate: 10%; at least 2.0-fold (0.30 log units) between middle value and limit.
By their numbers in this assay, from the lowest: compound 2; then compound 1; then compound 3. At a limit, above all of these: compound 4.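

In this assay compound 4 is reported only as a limit: (the limit of > 3000 nM in this assay, at which 1 of the 4 values shown sits). Hydrogen on this aromatic nitrogen gives a higher number than each of the three chains: heptyl (an at least 20-fold higher number from compound 1 to compound 4 (1.30 log units; beyond the scatter)), 3-(ethylsulfanyl)propyl (an at least 5.6-fold higher number from compound 3 to compound 4 (0.75 log units; beyond the scatter)) and 2-(2-hydroxyethoxy)ethyl (an at least 71-fold higher number from compound 2 to compound 4 (1.85 log units; beyond the scatter)). The earlier compounds shown here showed only that these chains differ from one another, whereas this result shows that having any of them gives a lower number than having none.

From the compounds shown here alone, the true size of each step stays open. So does whether a short methyl group, or a chain ending in an amine or a carboxylic acid, would also keep the number low.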